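This account rests on a few compounds, and the source may have more. Where it says the series, first, only, none or still open, it means among the compounds named here.

Measured in an ADME assay on BHK-21 cells (Mesocricetus auratus) for cytotoxicity, read by MTT assay, with a stated time of 96 h; a lower number here means that less compound is tolerated, a higher number that more compound is tolerated:
Compound 1, `c1ccc(/N=N/N2CCCCC2)cc1`, gives > 100000 nM, which is a limit of the assay and not a number.
Compound 2, `c1ccc(/N=N/N2CCCC2)cc1`, gives >= 100000 nM, which is a limit of the assay and not a number.
Compound 3, `Clc1ccc(/N=N/N2CCCC2)cc1`, gives > 100000 nM, which is a limit of the assay and not a number.

None of the three measured compounds yielded a numerical value: each stopped at the ceiling of what the assay tests. Two of the three values sit at the limit of > 100000 nM in this assay, at which 2 of the 3 values shown sit, and one at the limit of >= 100000 nM in this assay, at which 1 of the 3 values shown sits. Compound 2 and compound 3 differ in one place, (chloro in place of hydrogen on an aromatic carbon); the measured step that the two limits leave unreadable from compound 2 to compound 3 cannot be read, as both ends are limits. Compound 1 and compound 2 carry the two cores, and the difference between those cores is not broken down here.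

Compound 4, `Clc1ccc(/N=N/N2CCCCC2)cc1`, has not yet been measured in this assay. It differs from compound 1 by chloro in place of hydrogen on an aromatic carbon. The two descriptions of the place are not identical word for word: in compound 4 the chloro stands para to a group of 8 heavy atoms, in compound 3 para to a group of 7 heavy atoms, so the change is the same kind of change rather than the same change.

The expectation for compound 4 rests on compound 1 sitting at the limit of > 100000 nM in this assay, at which 2 of the 3 values shown sit, and on compound 3 sitting at the same limit of > 100000 nM in this assay, at which 2 of the 3 values shown sit, after the same kind of change. The step of a number no higher from compound 1 to compound 4 (the limit leaves the size open) is expected to be essentially no change, set beside the unreadable measured step that the two limits leave unreadable from compound 2 to compound 3. Compound 4 is therefore estimated to give about 100000 nM, somewhere between 50000 nM and 300000 nM, and most probably to be reported again only as a limit.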

Compound 4, half-maximal cytotoxic concentration: > 100000 nM
Compound 4 was reported as a limit (the forecaster's own chance of this, stated with the estimate: 85%); the middle value sits exactly at the limit.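

In this assay compound 4 gives > 100000 nM, which is a limit of the assay and not a number. Compound 1 also stands at a limit, so the step from compound 1 to compound 4 cannot be read. The compounds shown leave open whether chloro in place of hydrogen on an aromatic carbon changes the tolerated concentration at all, with most values resting at one ceiling: the limit of > 100000 nM in this assay, at which 3 of the 4 values shown sit.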